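A few compounds are considered here, and "the series" means these few. Any claim that something is new, unique, unknown or untested is made for them only; others in the source may bear on it.

Measured so far:
- Compound 1 `CN(c1ncco1)c1cnc(NCc2c(F)ccc3c2CCO3)n2cnnc12`: 11 mL.min-1.g-1
- Compound 2 `C[C@@H]1CC(=O)N(c2cnc(NCc3c(F)ccc4c3CCO4)n3cnnc23)C1`: < 3 mL.min-1.g-1, a limit
- Compound 3 `COCCC(=O)Nc1cnc(NCc2c(F)ccc3c2CCO3)n2cnnc12`: < 3 mL.min-1.g-1, a limit

All three were tested in an ADME assay on microsomes from liver (Homo sapiens) for metabolic stability, read by LC-MS, using NADPH, with stated times of 5 min and 30 min, tested at 1 uM; on this read-out lower numbers stand for slow clearance and higher numbers for fast clearance. Compound 3 has no exact number, only the limit < 3 mL.min-1.g-1.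

Compound 4 `CC1(C)CC(=O)N(c2cnc(NCc3c(F)ccc4c3CCO4)n3cnnc23)C1` has not yet been measured. It differs from compound 3 as follows: 4,4-dimethyl-2-oxopyrrolidin-1-yl in place of ((2-methoxyethyl)carbonyl)amino on an aromatic carbon. The 4,4-dimethyl-2-oxopyrrolidin-1-yl group replaces the ((2-methoxyethyl)carbonyl)amino group.

Among the compounds with values here, three measured steps bear on this. Two are an at least 3.6-fold lower number from compound 1 to compound 2 (0.56 log units; beyond the scatter) and an at least 3.6-fold lower number from compound 1 to compound 3 (0.56 log units; beyond the scatter). The third, a step that the two limits leave unreadable from compound 2 to compound 3, gives no size.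

With the limit of < 3 mL.min-1.g-1 in this assay, at which 2 of the 3 values shown sit, as the guide, the step expected is a number no lower from compound 3 to compound 4 (the limit leaves the size open), none beyond the scatter. Compound 4 is expected at 3 mL.min-1.g-1, with an estimated range of 1.5 mL.min-1.g-1 to 7 mL.min-1.g-1.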

Compound 4, intrinsic clearance in microsomes: 16 mL.min-1.g-1
Compound 4: the middle estimate sits 5.3-fold (0.73 log units) below what was measured; measured number outside the range, above it.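

In this assay, 4,4-dimethyl-2-oxopyrrolidin-1-yl in place of 4-methyl-2-oxopyrrolidin-1-yl gives an at least 5.3-fold higher number from compound 2 to compound 4 (0.72 log units; beyond the scatter), so one more methyl group on this ring is enough to lose the low clearance seen with the ring at this place. The change from the open chain, an at least 5.3-fold higher number from compound 3 to compound 4 (0.72 log units; beyond the scatter), is likewise only a minimum in size, since it starts from a limit: the limit of < 3 mL.min-1.g-1 in this assay, at which 2 of the 4 values shown sit. Against methyl(1,3-oxazol-2-yl)amino, the step is a 1.5-fold higher number from compound 1 to compound 4 (0.16 log units; within the scatter), so those two cannot be told apart. Still open, as far as these compounds go, is how an unsubstituted 2-oxopyrrolidin-1-yl ring, a 2-oxopiperidin-1-yl ring or a morpholine would read at this position.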